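The source may report more compounds than this note shows. Statements on the series, on what has been measured and on what is new or still open speak of the compounds shown alone.

Measured so far in a functional assay on DU-145 cells (Homo sapiens) for cytotoxicity, read by trypan blue exclusion, with a stated time of 96 h; on this read-out lower numbers stand for stronger inhibition of growth and higher numbers for weaker inhibition of growth:
- compound 1, `COc1ccc(NS(=O)(=O)/C=C/c2c(OC)cc(OC)cc2OC)cc1`: 75 nM
- compound 2, `COc1cc(OC)c(/C=C/S(=O)(=O)Nc2ccc(OC)c(O)c2)c(OC)c1`: 50 nM
- compound 3, `COc1cc(OC)c(/C=C/S(=O)(=O)Nc2ccc(OC)c(N)c2)c(OC)c1`: 8 nM

Compound 3 has the lowest number of the three, and the gaps to both others lie beyond the scatter. The two steps are a 9.4-fold lower number from compound 1 to compound 3 (0.97 log units; beyond the scatter) and a 6.3-fold lower number from compound 2 to compound 3 (0.80 log units; beyond the scatter). The remaining step, a 1.5-fold lower number from compound 1 to compound 2 (0.18 log units; within the scatter), stays within the scatter.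

Compound 4, `COc1cc(OC)c(/C=C/S(=O)(=O)Nc2ccc(OC)c(NC(C)(C)C(=O)O)c2)c(OC)c1`, is not yet measured. Its structure departs from compound 3 as follows: 1-carboxy-1-methylethyl in place of hydrogen on a nitrogen on an aromatic ring. In words, this is 1-carboxy-1-methylethyl in place of hydrogen on a nitrogen on an aromatic ring.

Within the data shown here, no measured step places anything on that nitrogen, so the evidence is indirect. Among the measured compounds shown here, the two steps ending at compound 3 show only that the amino compound stands apart from its two neighbours. Part of that gap may be given back once the amino hydrogen is replaced, so a modest move towards a higher number is expected in this assay. The expected step is a 4.4-fold higher number from compound 3 to compound 4 (0.64 log units; beyond the scatter). The estimated value for compound 4 is 35 nM, within an expected range of 8 nM to 200 nM.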

Compound 4, concentration for 50% growth inhibition: 150 nM
For compound 4 the middle estimate is 4.3-fold (0.63 log units) below the measured one; the range from low to high includes it.
By their numbers in this assay, from the lowest: compound 3; then compounds 2, 1 and 4 (each within the scatter of the next, the first and the last beyond it).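

In this assay, among these compounds, the nitrogen on the aromatic ring does not keep the standing of the amino compound once its hydrogen is replaced: 1-carboxy-1-methylethyl there gives a 19-fold higher number from compound 3 to compound 4 (1.27 log units; beyond the scatter) as a large step, the first measured change at this atom. Set against hydroxy on the same aromatic carbon, the (1-carboxy-1-methylethyl)amino group gives a 3.0-fold higher number from compound 2 to compound 4 (0.48 log units; beyond the scatter) as a modest step, while against hydrogen there it gives a 2.0-fold higher number from compound 1 to compound 4 (0.30 log units; within the scatter) and so stands apart from neither end of that comparison, leaving none of the amino compound's lead. No measurement at hand gives a reason for these steps. The compounds shown leave open whether the carboxylic acid or the methyl groups on the carbon attached to the nitrogen carry the step. A methyl ester, a simple methyl or acetyl group on that nitrogen, or an unbranched chain ending in a carboxylic acid would separate these parts.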